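From chloro to fluoro on compound 3

The source may hold more compounds than are shown below. What is called first, only, known or untested is meant among the compounds shown, and "the series" means these compounds.

Of the compounds shown here, three sharing one core have been measured in a functional assay on PC-3 cells (Homo sapiens); on this read-out higher numbers stand for weaker inhibition of growth and lower numbers for stronger inhibition of growth. Compound 1 `O=S(=O)(/C=C/c1ccc(Cl)cc1Cl)Cc1ccc(Nc2ncnc3ccccc23)cc1` gives 19000 nM. Compound 2 `O=S(=O)(/C=C/c1ccc(F)cc1Cl)Cc1ccc(Nc2ncnc3ccccc23)cc1` gives 100000 nM. Compound 3 `O=S(=O)(/C=C/c1ccc(Cl)cc1Cl)Cc1ccc(Nc2ncnc3cc(Cl)ccc23)cc1` gives 38000 nM, the second highest of the three numbers. That value cannot be told apart from compound 1 and lies lower than the number for compound 2.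

Compound 4 `O=S(=O)(/C=C/c1ccc(F)cc1Cl)Cc1ccc(Nc2ncnc3cc(Cl)ccc23)cc1`, not yet measured, differs from compound 3 in one place: fluoro in place of chloro on an aromatic carbon. Fluoro takes the place of chloro on an aromatic carbon, para to a large group and meta to a chloro group.

Going by the values given here, the closest precedent is the same exchange, which gave a 5.3-fold higher number from compound 1 to compound 2 (0.72 log units; beyond the scatter). The other measured step, a 2.0-fold higher number from compound 1 to compound 3 (0.30 log units; within the scatter), adds the chloro group that compound 3 carries and that compound 4 keeps. That group made no difference beyond the scatter, so the exchange may well read across, although it has been seen in one pair only. A rise of modest size is therefore expected in this assay, pointing to weaker inhibition of growth. The expected size is a 3.2-fold higher number from compound 3 to compound 4 (0.50 log units; beyond the scatter), set a little below the precedent given that single pair. For compound 4 the estimate is 120000 nM, with an expected range of 45000 nM to 320000 nM.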

Compound 4, concentration for 50% growth inhibition: 73000 nM
Compound 4: the middle estimate sits 1.6-fold (0.22 log units) above what was measured; low and high end bracket the measured number.
By their numbers in this assay, from the lowest: compounds 1, 3, 4 and 2 (each within the scatter of the next, the first and the last beyond it).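

With the added chloro group on the core, the change from 2,4-dichlorophenyl to 2-chloro-4-fluorophenyl in this assay gives a 1.9-fold higher number from compound 3 to compound 4 (0.28 log units; within the scatter), so a step that lay beyond the scatter on the core of compound 1 stays within it on this core: the same change on two cores in this assay, a 5.3-fold higher number (0.72 log units; beyond the scatter) from compound 1 to compound 2 and a 1.9-fold higher number (0.28 log units; within the scatter) from compound 3 to compound 4, 2.7-fold (0.44 log units) apart, beyond the scatter of two such steps.

The added chloro group, read on the fluoro-bearing pair, gives a 1.4-fold lower number from compound 2 to compound 4 (0.14 log units; within the scatter), which is also within the scatter, yet its two steps differ by more than the scatter allows: the same change on two cores in this assay, a 2.0-fold higher number (0.30 log units; within the scatter) from compound 1 to compound 3 and a 1.4-fold lower number (0.14 log units; within the scatter) from compound 2 to compound 4, 2.7-fold (0.44 log units) apart, beyond the scatter of two such steps.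

Fluoro in place of chloro at this position, para to a large group, therefore does not carry over at one size between the two cores, and the two changes do not simply add up across these four compounds.

Going by these compounds alone, it remains open how a methoxy group or an amine at this same position would read in this assay, since chloro and fluoro are the only two groups compared there. Also open, going by these compounds, is whether the gap between the two cores would persist with a nitrile in place of the added chloro group, as each core offers a single pair for this exchange.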